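Sulfonamide aryl swap from compound 2 to compound 4

The source may report more compounds than this note shows. Statements on the series, on what has been measured and on what is new or still open speak of the compounds shown alone.

In a functional assay on A2780 cells (Homo sapiens) for antiproliferative activity, read by MTT assay, with a stated time of 72 h (a lower number here means a stronger inhibitor of growth, a higher number a weaker inhibitor of growth), compound 2 `COc1cc(OC)c(/C=C/S(=O)(=O)Nc2ccc(OC)nc2)c(OC)c1` gives 380 nM, and compound 3 `CCOc1cc(OC)cc(OC)c1/C=C/S(=O)(=O)Nc1ccc(OC)nc1` gives 470 nM, a pair within the scatter of each other. Compound 1 `COc1cc(OC)c(/C=C/S(=O)(=O)Cc2cnc(OC)c(OC)c2)c(OC)c1` gives 930 nM, beyond the scatter from compound 2.

Compound 4 `CCOc1ccc(NS(=O)(=O)/C=C/c2c(OC)cc(OC)cc2OC)cc1` carries 4-ethoxyphenyl in place of 6-methoxypyridin-3-yl on a sulfonamide nitrogen.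

Within the data shown here, only one measured step bears on this change, and only in part. The step of a 1.2-fold higher number from compound 2 to compound 3 (0.09 log units; within the scatter) adds a methyl in place of a hydrogen on a saturated chain carbon bound to an oxygen on an aromatic ring, while compound 3 keeps the 6-methoxypyridin-3-yl. Among the measured compounds shown here, no measured pair covers the loss of the ring nitrogen, so the estimate stays wide. A small move towards a higher number in this assay is expected, probably not clearly beyond the scatter.

The expected size of the change is a 1.3-fold higher number from compound 2 to compound 4 (0.12 log units; within the scatter). For compound 4 the estimated value is 500 nM, with an expected range of 170 nM to 1500 nM.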

Compound 4, concentration for 50% growth inhibition: 310 nM
Compound 4: middle estimate off by 1.6-fold (0.21 log units), on the high side, and the stated range covers the measured number.
By their numbers in this assay, from the lowest: compounds 4, 2, 3 and 1 (each within the scatter of the next, the first and the last beyond it).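

In this assay the change on the sulfonamide nitrogen gives a 1.2-fold lower number from compound 2 to compound 4 (0.09 log units; within the scatter) and so leaves the number within the scatter. The earlier compounds shown here all carry a ring with a hetero atom at this end of the molecule, whereas compound 4 shows that 4-ethoxyphenyl, a six-membered aromatic ring of carbon only, is tolerated at this place with no loss beyond the scatter. No supporting measurement bears on this result, and the data give no reason for it.

The ring nitrogen and the alkoxy chain change together in this step, so their separate contributions cannot be told apart from compound 2 and compound 4 alone. Also open, as far as these compounds go, is how the sulfonamide series responds when the ethoxy group of compound 4 gives way to an amine or a carboxylic acid.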